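Working notes: methoxycarbonyl in place of fluoro

The compounds below may be only part of what the source reports. "The series", "measured", "known", "first", "only" and "open" are said of these compounds alone.

Compound 1 `NS(=O)(=O)c1ccc(S(=O)(=O)CC(O)CO)cc1` gives 9.35
Compound 2 `NS(=O)(=O)c1ccc(S(=O)(=O)CCCO)c(F)c1` gives 9.02
Compound 3 `NS(=O)(=O)c1ccc(SCCO)c(C(=O)O)c1` gives 10.5

In a physicochemical assay for acid dissociation, compound 2 stands lowest of the three at 9.02 with compound 1 nearest and compound 3 furthest. Both gaps lie beyond the scatter.

Compound 4 `COC(=O)c1cc(S(N)(=O)=O)ccc1S(=O)(=O)CCCO` has not yet been measured. It differs from compound 2 by methoxycarbonyl in place of fluoro on an aromatic carbon and that carbon is ortho to a group of 7 heavy atoms and meta to a sulfamoyl group.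

Among the compounds with values here, no two measured compounds differ in one place only, so no measured step speaks directly to this exchange. The high value of compound 3 at 10.5 is therefore not carried over. The expectation starts instead from compound 2 at 9.02 and allows for no step beyond the scatter in this assay either to a higher or to a lower read-out. The expected change is a number 0.03 log units higher from compound 2 to compound 4 (within the scatter) in this reading, which remains a working assumption until a number is available.

Compound 4 is estimated at 9.05 with an expected range from 8.7 to 9.4 in this measurement.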

Compound 4, acid dissociation constant: 8.9
Beside the measured number, compound 4's estimate is 0.15 log units above it; low and high end bracket the measured number.
By their numbers in this assay, from the lowest: compounds 4 and 2 (each within the scatter of the next); then compound 1; then compound 3.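

In this assay, the step of a number 0.12 log units lower from compound 2 to compound 4 (within the scatter) gives the series its first reading across a single exchange, methoxycarbonyl in place of fluoro on an aromatic carbon that is ortho to a group of 7 heavy atoms and meta to a sulfamoyl group. At this position, then, a single fluorine atom can give way to a group of 4 heavy atoms, with 2 hydrogen-bond acceptors and 1 double bond outside aromatic rings, without the read-out moving beyond the scatter, something compound 1 and compound 3 could not show since each differs from compound 2 in more than one place. Nothing at hand bears on the reason for this result.

The steps from compound 1 and compound 3 to compound 4 cannot be read, as each pair differs in more than one place, so the influence of the remaining differences in the series stays unresolved. This single exchange also leaves open whether an amine or a trifluoromethyl group on the same aromatic carbon would stay within the scatter of compound 2 in this assay as well.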